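Methoxy in place of ethyl on the carbonyl carbon

The source may report more compounds than this note shows. Statements on the series, on what has been measured and on what is new or still open speak of the compounds shown alone.

Compound 1 `C[C@H]1CN(C(=O)c2ccco2)c2cc(-c3ccc(S(C)(=O)=O)cc3)ccc2N1C(=O)C1CC1` gives > 0.4 h in an ADME assay on a cell-free system (plasma, Mus musculus) for metabolic stability; a lower number here means that the compound disappears faster, a higher number that the compound lasts longer; this is a limit of the assay, not a number.
Compound 2 `CCC(=O)N1c2ccc(-c3ccc(S(C)(=O)=O)cc3)cc2N(C(=O)c2ccco2)C[C@@H]1C` gives 0.3 h in this assay.

Compound 2 thus stands on the only number shown; the other value is a limit. Among the compounds with values here, the one measured step reads an at least 1.3-fold lower number from compound 1 to compound 2 (0.12 log units; that floor lies within the scatter), and its floor comes from the limit of > 0.4 h in this assay, at which 1 of the 2 values shown sits, so it says little about direction.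

Compound 3 `COC(=O)N1c2ccc(-c3ccc(S(C)(=O)=O)cc3)cc2N(C(=O)c2ccco2)C[C@@H]1C` differs from compound 2 by methoxy in place of ethyl on a carbonyl carbon. Within the data shown here, no measured step swaps ethyl for methoxy at this position, and the only neighbouring step, ethyl from cyclopropyl, lies within the scatter. Nothing here therefore points to a change beyond the scatter in this assay.

Compound 3 is expected to give about 0.3 h, between 0.15 h and 0.7 h. This estimate means a step of no change at the digits printed from compound 2 to compound 3 (within the scatter), which is expected to stay within the scatter.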

Compound 3, half-life: 0.367 h
For compound 3 the middle estimate is 1.2-fold (0.09 log units) below the measured one; the range from low to high includes it.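

Putting methoxy on this carbonyl carbon in place of ethyl, which turns propanoyl into methoxycarbonyl, gives a 1.2-fold higher number from compound 2 to compound 3 (0.09 log units; within the scatter) in this assay. Within the data shown here, this is the first measured step at this position that has a number at both ends, and it shows that this swap leaves the half-life within the scatter. The comparison with cyclopropyl reads an at least 1.0-fold lower number from compound 1 to compound 3 (0.03 log units; that floor lies within the scatter), and its floor says little about direction: the limit of > 0.4 h in this assay, at which 1 of the 3 values shown sits.

The compounds shown leave open whether a group of another kind on this carbonyl carbon, such as an amine or a longer chain like butyl, would move the half-life beyond the scatter. From the compounds shown here alone, the true half-life of compound 1 also stays open: its value is a limit and not a number.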